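This account rests on a few compounds, and the source may have more. Where it says the series, first, only, none or still open, it means among the compounds named here.

Values in a functional assay on L02 cells (Homo sapiens) for inhibition, read by Griess assay, with stated times of 1 h and 24 h; a lower number here means a stronger inhibitor, a higher number a weaker inhibitor:

- Compound 1 `CC(C)Nc1nc(/C=C/c2ccccc2)nc2ccsc12`: > 1000000 nM
- Compound 2 `CN(C)c1nc(/C=C/c2ccccc2)nc2ccsc12`: > 1000000 nM
- Compound 3 `CN(c1ccccc1)c1nc(/C=C/c2ccccc2)nc2ccsc12`: > 1000000 nM

Compound 3 stands at > 1000000 nM, which is a limit of the assay and not a measured number. It has company there: the limit of > 1000000 nM in this assay, at which 3 of the 3 values shown sit. So this assay gives no ranking among these compounds.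

The next change gives compound 4 `Brc1ccc(Nc2nc(/C=C/c3ccccc3)nc3ccsc23)cc1`, which keeps the shared core and replaces the amine group: (4-bromophenyl)amino in place of methyl(phenyl)amino on an aromatic carbon. In words, this is (4-bromophenyl)amino in place of methyl(phenyl)amino on an aromatic carbon.

Three measured steps changed the group at this same place: a step that the two limits leave unreadable from compound 1 to compound 2, a step that the two limits leave unreadable from compound 1 to compound 3 and a step that the two limits leave unreadable from compound 2 to compound 3. Each runs between two limits, so none offers a size to carry over or a direction to follow. For the measured compounds named here, every change at this place so far, including a step that the two limits leave unreadable from compound 2 to compound 3, ended at the limit, and compound 4 is therefore expected most likely to end there too. A number just inside the limit remains possible, which would mean a weak inhibitor.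

The estimate corresponds to an expected at least 1.2-fold lower number from compound 3 to compound 4 (0.09 log units; that floor lies within the scatter), and its size is uncertain. The estimated value for compound 4 is 800000 nM, with an expected range of 100000 nM to 1000000 nM.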

Compound 4, half-maximal inhibitory concentration: > 1000000 nM
Compound 4 gave a limit, no number (the forecaster's own chance of this, stated with the estimate: 60%); at least 1.2-fold (0.09 log units) between middle value and limit.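

In this assay compound 4 gives > 1000000 nM, which is a limit and not a number. For the compounds shown here, no step linking compound 4 to compound 1, compound 2 or compound 3 can therefore be read, and the result comes down to one shared line: the limit of > 1000000 nM in this assay, at which 4 of the 4 values shown sit. The compounds shown leave open whether changing the amine group at this place can alter inhibition at all.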